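Amide to urea at the anilide carbonyl

A few compounds are considered here, and "the series" means these few. Any claim that something is new, unique, unknown or untested is made for them only; others in the source may bear on it.

Compound 2 `COc1cc(-c2nn(-c3cccc(NC(=O)c4cccc(C(F)(F)F)c4)c3)cc2-c2ccncc2)ccc1Cl` stands in a functional assay on SF-268 cells (Homo sapiens) for inhibition, read by sulforhodamine B assay, with a stated time of 48 h (a lower number here means a stronger inhibitor of growth, a higher number a weaker inhibitor of growth), at a limit, > 50000 nM, which is the limit of > 50000 nM in this assay, at which 1 of the 3 values shown sits. The two ureas in the set give numbers: compound 1 `COc1cc(-c2nn(-c3cccc(NC(=O)Nc4cc(C(F)(F)F)cc(C(F)(F)F)c4)c3)cc2-c2ccncc2)ccc1Cl` gives 2430 nM in this assay, and compound 3 `O=C(Nc1cccc(-n2cc(-c3ccncc3)c(-c3ccc(Cl)c(O)c3)n2)c1)Nc1ccc(Cl)c(Cl)c1` gives 10900 nM. Compound 4 `COc1cc(-c2nn(-c3cccc(NC(=O)Nc4cccc(C(F)(F)F)c4)c3)cc2-c2ccncc2)ccc1Cl` is not yet measured; it differs from compound 2 by (3-(trifluoromethyl)phenyl)amino in place of 3-(trifluoromethyl)phenyl on a carbonyl carbon, so compound 4 carries the same urea linkage that compound 1 and compound 3 have. A step towards stronger growth inhibition is expected, an at least 10-fold lower number from compound 2 to compound 4 (1.00 log units; beyond the scatter), its size resting on the values of compound 1 at 2430 nM and compound 3 at 10900 nM. Compound 4 is estimated to reach 5000 nM in this assay, with a range from 1500 nM to 20000 nM.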

Compound 4, concentration for total growth inhibition: 5430 nM
For compound 4 the middle estimate is 1.1-fold (0.04 log units) below the measured one; measured number inside the range.
By their numbers in this assay, from the lowest: compound 1; then compounds 4 and 3 (each within the scatter of the next). At a limit, above all of these: compound 2.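

In this assay, within the data shown here, (3-(trifluoromethyl)phenyl)amino in place of 3-(trifluoromethyl)phenyl on the carbonyl carbon gives an at least 9.2-fold lower number from compound 2 to compound 4 (0.96 log units; beyond the scatter), the only matched comparison of urea and amide linkages here. On these data alone, the size of that step stays open at one end, since compound 2 sits at a limit: the limit of > 50000 nM in this assay, at which 1 of the 4 values shown sits. With the urea kept, hydrogen in place of trifluoromethyl on an aromatic carbon gives a 2.2-fold higher number from compound 1 to compound 4 (0.35 log units; beyond the scatter), a smaller step.

As far as these compounds go, whether the new amine hydrogen is needed remains open; an N-methyl urea or a carbamate would separate that from the change in linkage.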